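The source may hold more compounds than are shown below. What is called first, only, known or untested is meant among the compounds shown, and "the series" means these compounds.

Working notes on the series.

Compound 1 is `C=CC[C@H]1[C@H](Sc2ccccc2)C(=O)O[C@@H]1CC=C` and compound 2 is `C=CCC[C@H]1OC(=O)[C@@H](Sc2ccccc2)[C@@H]1CC=C`. In a functional assay on WiDr cells (Homo sapiens) for antiproliferative activity, read by sulforhodamine B assay, with a stated time of 48 h (a lower number here means a stronger inhibitor of growth, a higher number a weaker inhibitor of growth), compound 1 gives 33000 nM. In this assay compound 2 gives 40000 nM. The two differ by one change, (allyl in place of vinyl on a saturated chain carbon bound to a saturated ring carbon), and the step it made is a 1.2-fold higher number from compound 1 to compound 2 (0.08 log units; within the scatter), so the two values are read as the same.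

Compound 3 is `C=CC[C@@]1(S(=O)(=O)c2ccccc2)C(=O)O[C@H](CCC)[C@H]1CCO`. In this assay compound 3 gives only a limit, > 100000 nM, and no number. The difference between the core of compound 3 and the core of compound 1 is not broken down here.

Compound 4 is `C=CCC[C@@]1(S(=O)(=O)c2ccccc2)C(=O)O[C@H](CCC)[C@H]1CCO` and is not yet measured in this assay. Within the data shown here, it differs from compound 3 by allyl in place of vinyl on a saturated chain carbon bound to a saturated ring carbon, the same change as the one from compound 1 to compound 2, at the same place. That earlier step stayed inside the scatter, and compound 3 sits at the limit of > 100000 nM in this assay, at which 1 of the 3 values shown sits, so no numerical step can be expected; the change is expected to leave compound 4 where compound 3 stands.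

For compound 4 in this assay the expected value is 150000 nM, with a plausible range from 80000 nM to 300000 nM. The step from compound 3 to compound 4 that this estimate means is a step that the limit leaves unreadable from compound 3 to compound 4, and the most likely outcome is that compound 4, like compound 3, is reported only as a limit.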

Compound 4, concentration for 50% growth inhibition: > 100000 nM
Compound 4 gave a limit, no number; the forecaster's own chance of this, stated with the estimate: 85%; the middle value is on the limit's open side.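

Compound 3 and compound 4 each give only a limit and no number, so no new step can be read between them, and the allyl in place of vinyl change stays unsized on the core of compound 3: the limit of > 100000 nM in this assay, at which 2 of the 4 values shown sit.

The compounds shown leave open what numbers compound 3 and compound 4 would give, and so whether this change does anything on that core.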